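Swapping the Aryl Group on an Oxazole Piperidine Amide

The source may report more compounds than this note shows. Statements on the series, on what has been measured and on what is new or still open speak of the compounds shown alone.

Measured so far:
- compound 1 `Cc1oc(-c2ccccc2Cl)nc1CN1CCC(C(=O)NCCCN2C[C@H](C)C[C@H](C)C2)CC1`: 352 10^-6 cm/s
- compound 2 `Cc1ccccc1-c1nc(CN2CCC(C(=O)NCCCN3CCCCC3)CC2)c(C)o1`: 34.5 10^-6 cm/s
- compound 3 `Cc1ccccc1-c1nc(CN2CCC(C(=O)NCCCN3CCCC(C(C)C)C3)CC2)c(C)o1`: "not determined" (no result reported)

In a physicochemical assay for permeability, using PAMPA (a lower number here means that the compound crosses the layer more slowly, a higher number that the compound crosses the layer faster), compound 1 gives 352 10^-6 cm/s, the highest of the two numbers available. Compound 2 lies far below it, a gap well beyond the usual scatter of this assay. Compound 3 has no reported number. Among the compounds with values here, no single-point step between measured compounds is available, so nothing shows how a change at the aryl group alone moves this assay.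

Compound 4 `Cc1cc(C)cc(-c2nc(CN3CCC(C(=O)NCCCN4C[C@H](C)C[C@H](C)C4)CC3)c(C)o2)c1` differs from compound 1 in one place: 3,5-dimethylphenyl in place of 2-chlorophenyl on an aromatic carbon. Because compound 1 already gives 352 10^-6 cm/s, this assay is expected to stay close to that level for compound 4. The estimated step of a 1.2-fold lower number from compound 1 to compound 4 (0.07 log units; within the scatter) is expected to lie within the scatter. Compound 4 is expected to give about 300 10^-6 cm/s, ranging from 150 10^-6 cm/s to 600 10^-6 cm/s.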

Compound 4, apparent permeability: 864 10^-6 cm/s
Compound 4: the middle estimate sits 2.9-fold (0.46 log units) below what was measured; measured number above the stated range.
By their numbers in this assay, from the lowest: compound 2; then compound 1; then compound 4.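

In this assay this aromatic carbon of the shared core proves sensitive, with 3,5-dimethylphenyl in place of 2-chlorophenyl giving a 2.5-fold higher number from compound 1 to compound 4 (0.39 log units; beyond the scatter) even though compound 1 already stood high. Both groups are six-membered aromatic carbon rings without hydrogen-bond donors or acceptors, so the shift comes with those counts unchanged. Nothing at hand indicates why the number moved. The compounds shown do not separate the loss of chlorine from the gain of two methyl groups. From the compounds shown here alone, how a methoxy group or an amine on that phenyl ring would behave remains open.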